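The source may report more compounds than this note shows. Statements on the series, on what has been measured and on what is new or still open speak of the compounds shown alone.

In a physicochemical assay for solubility, read by LC-MS, using the shake flask method, measured as thermodynamic solubility, with a stated time of 24 h, at pH 6.5 (a lower number here means a less soluble compound, a higher number a more soluble compound), compound 1 (`O=C(O)c1ccc(-n2cc(CO[C@H]3O[C@H](CO)[C@@H](O)[C@H](O)[C@@H]3O)nn2)cc1`) gives > 3000 ug/mL, which is a limit of the assay. Compound 2 (`OC[C@H]1O[C@H](OCc2cn(-c3ccc(F)cc3)nn2)[C@@H](O)[C@@H](O)[C@@H]1O`) gives > 3000 ug/mL, also a limit. Compound 3 (`OC[C@H]1O[C@H](n2cc(-c3ccccc3)nn2)[C@@H](O)[C@@H](O)[C@@H]1O`) stands at > 3000 ug/mL, again a limit and not a number. Within the data shown here, the series so far therefore shows only (the limit of > 3000 ug/mL in this assay, at which 3 of the 3 values shown sit). Compound 4 (`OC[C@H]1O[C@H](n2cc(-c3cccc(Cl)c3)nn2)[C@@H](O)[C@@H](O)[C@@H]1O`) differs from compound 3 by chloro in place of hydrogen on an aromatic carbon, which is phenyl to 3-chlorophenyl. Among the measured compounds shown here, the one measured step, a step that the two limits leave unreadable from compound 1 to compound 2, replaces carboxy with fluoro on an aromatic carbon and offers no size to carry over. A modest fall is expected, and the result may still sit at the limit. The expected change is an at least 1.6-fold lower number from compound 3 to compound 4 (0.22 log units; that floor lies within the scatter). For compound 4 the estimated solubility is 1800 ug/mL, with an expected range of 500 ug/mL to 3000 ug/mL.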

Compound 4, solubility: 705 ug/mL
Beside the measured number, compound 4's estimate is 2.6-fold (0.41 log units) above it; the range from low to high includes it.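

In this assay, chloro in place of hydrogen on an aromatic carbon, meta to a large group, brings an at least 4.2-fold lower number from compound 3 to compound 4 (0.62 log units; beyond the scatter), so this position responds to a single chlorine. That size is only a floor, since the value for compound 3 is a limit and not a number. Until this step, the series offered no readable size: the limit of > 3000 ug/mL in this assay, at which 3 of the 4 values shown sit.

As far as these compounds go, whether an amine, a carboxylic acid or a methyl at this position would lower the number as far remains open. So does the effect of chloro elsewhere on the aromatic ring.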